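Expected Effect of a Third Methoxy Group

The source may hold more compounds than are shown below. What is called first, only, known or untested is meant among the compounds shown, and "the series" means these compounds.

Compound 1 `COc1ccc(C(=O)/C=C/c2cc(-c3cc(OC)c(OC)c(OC)c3)n[nH]2)cc1OC` is the stronger of the two measured compounds: in a functional assay on RPMI-8226 cells (Homo sapiens) for inhibition, read by sulforhodamine B assay, with a stated time of 48 h (on this read-out higher numbers stand for weaker inhibition of growth and lower numbers for stronger inhibition of growth), compound 1 gives 1110 nM. Compound 2 `COc1cc(-c2cc(/C=C/C(=O)c3ccc(F)c(F)c3)[nH]n2)cc(OC)c1OC` differs from compound 1 only in the ring attached to the carbonyl carbon, and compound 2 gives 6010 nM; the step of a 5.4-fold higher number from compound 1 to compound 2 (0.73 log units; beyond the scatter) shows that replacing the 3,4-dimethoxyphenyl with 3,4-difluorophenyl weakens growth inhibition. Compound 3 `COc1cc(C(=O)/C=C/c2cc(-c3cc(OC)c(OC)c(OC)c3)n[nH]2)cc(OC)c1OC` has not yet been measured. It differs from compound 1 by methoxy in place of hydrogen on an aromatic carbon, so the ring on the carbonyl carbon now carries three methoxy groups instead of two. Among the compounds with values here, the only measured step concerns removing both methoxy groups in favour of fluorine, which does not directly tell what a third methoxy group does. With no closer guide, compound 3 is expected to differ little from compound 1, a 1.2-fold lower number from compound 1 to compound 3 (0.09 log units; within the scatter), within the usual scatter. The estimate for compound 3 in this assay is therefore 900 nM, with a range from 300 nM to 3000 nM.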

Compound 3, concentration for total growth inhibition: 2060 nM
Compound 3: middle estimate off by 2.3-fold (0.36 log units), on the low side, within the range that was stated.
By their numbers in this assay, from the lowest: compounds 1 and 3 (each within the scatter of the next); then compound 2.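

In this assay, putting a methoxy group in place of hydrogen at this position, ortho to a methoxy group and meta to a large group, gives a 1.9-fold higher number from compound 1 to compound 3 (0.27 log units; within the scatter), so compound 1 and compound 3 cannot be told apart here. The ring on the carbonyl carbon therefore accepts a third methoxy group without a change beyond the scatter, whereas the swap to 3,4-difluorophenyl gives a 5.4-fold higher number from compound 1 to compound 2 (0.73 log units; beyond the scatter). Nothing available explains why these two changes on the ring differ in outcome.

Going by these compounds, it remains open whether a hydroxyl group, an amine or a longer chain such as ethoxy at this position would also fit within the scatter of compound 1. The compounds shown also leave open whether a single fluorine beside the two methoxy groups of compound 1 would behave like methoxy or like the 3,4-difluorophenyl ring.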